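The source may hold more compounds than are shown below. What is called first, only, known or untested is meant among the compounds shown, and "the series" means these compounds.

Compound 1 `Cc1ccnc(N(CCN(C(C)C)C(C)C)C(=O)N(C)C)c1` gives 79% in a functional assay on the whole organism (stomach) for inhibition, with Canis familiaris (Canis lupus familiaris) as the target, at a dose of 10 mg/kg by the oral route; a lower number here means a weaker effect, a higher number a stronger effect of the compound at the dose given.
Compound 2 `Cc1cccc(N(CCN(C(C)C)C(C)C)C(=O)N(C)C)n1` gives 54% in this assay.

Among the compounds with values here, compound 2 stands lowest of the two measured numbers, and the only measured step, a number 25 percentage points lower from compound 1 to compound 2 (beyond the scatter), is a modest one. Compound 3 `CC(C)N(CCN(C(=O)N(C)C)c1ccc(Cl)cn1)C(C)C` differs from compound 2 by 5-chloropyridin-2-yl in place of 6-methylpyridin-2-yl on an amide-type nitrogen. Within the data shown here, no measured step exchanges a methyl for a chlorine on this ring, so the known step only shows that changing the substituent on the ring can move the inhibition by a modest amount in either direction. Compound 3 is therefore expected to show a moderate rise, a number 14 percentage points higher from compound 2 to compound 3 (beyond the scatter), with wide uncertainty. The estimate for compound 3 is 68%, expected between 45% and 88%.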

Compound 3, a percentage reported as inhibition, in the whole organism at one dose (the size of the read-out at that dose, not a potency): 44%
For compound 3 the middle estimate is 24 percentage points above the measured one; measured number outside the range, below it.
By their numbers in this assay, from the lowest: compounds 3 and 2 (each within the scatter of the next); then compound 1.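

The step of a number 10 percentage points lower from compound 2 to compound 3 (within the scatter) shows that, in this assay, 5-chloropyridin-2-yl and 6-methylpyridin-2-yl on the amide-type nitrogen cannot be told apart. The step of a number 35 percentage points lower from compound 1 to compound 3 (beyond the scatter) is large, so compound 1, with 4-methylpyridin-2-yl, stands clear of both other compounds as the strongest of the three. Nothing measured here explains these differences. As far as these compounds go, it remains open whether the higher number of compound 1 depends on its methyl group specifically. An ethyl, methoxy or amino group on the ring could test this.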